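A few compounds are considered here, and "the series" means these few. Any claim that something is new, unique, unknown or untested is made for them only; others in the source may bear on it.

Compounds measured in a functional assay on CHO cells for agonist activity at Free fatty acid receptor 1 (Homo sapiens), read by FLIPR and calcium flux, tested at 1 uM; on this read-out lower numbers stand for an effect already at smaller amounts and higher numbers for an effect only at larger amounts of compound:
compound 1, `O=C(O)CCc1ccc(NC(=O)c2nnc(COc3ccc(F)cc3)s2)cc1`, 5390 nM
compound 2, `O=C(O)CCc1ccc(NC(=O)c2nnc(COc3cccc(C(F)(F)F)c3)s2)cc1`, 3090 nM

Compound 2 gives the lowest of the two numbers in this assay; its nearest neighbour is compound 1, and the gap between them is within the scatter. Within the data shown here, the two compounds share a core and differ only in the aryl group on the oxygen on the saturated carbon, and the single step across that position, a 1.7-fold lower number from compound 1 to compound 2 (0.24 log units; within the scatter), stays within the scatter.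

Compound 3, `Cc1ccc(OCc2nnc(C(=O)Nc3ccc(CCC(=O)O)cc3)s2)cc1`, is not yet measured in this assay. It differs from compound 2 at the same position: 4-methylphenyl in place of 3-(trifluoromethyl)phenyl on an oxygen on a saturated carbon. Among the measured compounds shown here, the only step that bears on this kind of exchange is the one from compound 1 to compound 2, which moved the number by an amount within the scatter. For the measured compounds named here, nothing among the measured compounds points to a step beyond the scatter for a further aryl exchange at this oxygen, in either direction. For compound 3 the number in this assay is therefore expected to sit close to that of compound 2, at 4000 nM with a range from 1500 nM to 11000 nM, which means an estimated step of a 1.3-fold higher number from compound 2 to compound 3 (0.11 log units; within the scatter).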

Compound 3, half-maximal effective concentration: 2170 nM
For compound 3 the middle estimate is 1.8-fold (0.27 log units) above the measured one; the range from low to high includes it.
By their numbers in this assay, from the lowest: compounds 3, 2 and 1 (each within the scatter of the next, the first and the last beyond it).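

In this assay, 4-methylphenyl in place of 3-(trifluoromethyl)phenyl on the oxygen gives a 1.4-fold lower number from compound 2 to compound 3 (0.15 log units; within the scatter), so a second aryl exchange at this oxygen also stays within the scatter, and the three aryl groups seen so far do not separate cleanly from one another. Among these compounds, the new compound does, however, give the first step that lies beyond the scatter: methyl in place of fluoro on an aromatic carbon gives a 2.5-fold lower number from compound 1 to compound 3 (0.40 log units; beyond the scatter), a modest step that shows this position is not entirely flat, even though compound 2 lies within the scatter of both compound 1 and compound 3. No supporting data bear on why the methyl and fluoro compounds differ.

Still open, from the compounds shown here alone, is whether chloro, methoxy or an amine on the same aromatic carbon would extend the step seen with methyl or remain within the scatter of compound 3. Equally open, going by these compounds, is whether a saturated ring or a longer alkyl chain in place of the aryl group on the oxygen would be tolerated in this assay series.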